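Notes on the step from compound 3 to compound 4

The source may hold more compounds than are shown below. What is called first, only, known or untested is meant among the compounds shown, and "the series" means these compounds.

Measured so far in an assay on CHO cells for displacement of a labelled ligand from adenosine receptor A3 (Homo sapiens), read by scintillation counting, with a stated time of 45 min, tested at 1 uM, in the presence of a further agent that is not named here; on this read-out lower numbers stand for less inhibition and higher numbers for more inhibition at the one concentration tested (going by the name of the read-out):
compound 1, `CCCn1c(=O)[nH]c2nc(-c3ccc(S(=O)(=O)N4CCN(C)CC4)cc3)[nH]c2c1=O`, 7%
compound 2, `CCCn1c(=O)[nH]c2nc(-c3ccc(S(=O)(=O)N4CCN(c5ccccc5Br)CC4)cc3)[nH]c2c1=O`, 20%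
compound 3, `CCCn1c(=O)[nH]c2nc(-c3ccc(S(=O)(=O)N4CCN(c5ccccc5)CC4)cc3)[nH]c2c1=O`, 27%

Compound 3 has the highest of the three numbers: one step is a number 20 percentage points higher from compound 1 to compound 3 (beyond the scatter), beyond the scatter, while the other is only a number 7 percentage points higher from compound 2 to compound 3 (within the scatter), within the scatter. Compound 4, `CCCn1c(=O)[nH]c2nc(-c3ccc(S(=O)(=O)N4CCN(Cc5ccc(Br)cc5)CC4)cc3)[nH]c2c1=O`, differs from compound 3 by 4-bromobenzyl in place of phenyl on an amine nitrogen in a ring. For the measured compounds named here, two steps bear on this place: a number 13 percentage points higher from compound 1 to compound 2 (beyond the scatter) and a number 20 percentage points higher from compound 1 to compound 3 (beyond the scatter), both modest rises when an aromatic group replaces methyl, and a number 7 percentage points higher from compound 2 to compound 3 (within the scatter), showing that bromo on that group made no difference beyond the scatter. Going by the values given here, no measured step tests the 4-bromobenzyl itself, so an aromatic group kept at the ring nitrogen is expected to leave the number roughly where it is, a number 2 percentage points lower from compound 3 to compound 4 (within the scatter). Compound 4 is therefore estimated at 25%, within 8% to 42%.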

Compound 4, a percentage reported as inhibition, at one concentration (the size of the read-out at that concentration, not a potency): 28%
Beside the measured number, compound 4's estimate is 3 percentage points below it, and the stated range covers the measured number.
By their numbers in this assay, from the lowest: compound 1; then compounds 2, 3 and 4 (each within the scatter of the next).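

In this assay the change from phenyl to 4-bromobenzyl on the amine nitrogen gives (a number 1 percentage points higher from compound 3 to compound 4 (within the scatter)) and the change from 2-bromophenyl gives (a number 8 percentage points higher from compound 2 to compound 4 (within the scatter)), so this position accepts the larger group, with its extra saturated carbon, without a shift beyond the scatter. The step from the methyl group shows (a number 21 percentage points higher from compound 1 to compound 4 (beyond the scatter)), a modest rise like those seen with the two phenyl groups. No evidence on hand accounts for these steps.

On these data alone, whether the bromine of the 4-bromobenzyl group matters stays open, as unsubstituted benzyl would test. So does the effect of a non-aromatic group on this nitrogen, such as cyclohexyl or a chain ending in a carboxylic acid.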